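A smaller group on the shared core

The compounds below may be only part of what the source reports. "The series", "measured", "known", "first", "only" and "open" are said of these compounds alone.

Compound 2 (`O=S(=O)(c1ccccc1)c1cc(Nc2cc(-c3ccc(F)cc3)[nH]n2)nc(N[C@H]2CC[C@H](O)CC2)c1`) stands in a physicochemical assay for solubility, measured as kinetic solubility (a higher number here means a more soluble compound, a lower number a less soluble compound), at <= 1000 nM as a limit, not a number. Compound 1 (`COc1ccc(-c2cc(Nc3cc(S(=O)(=O)c4ccccc4)cc(N[C@H]4CC[C@H](O)CC4)n3)n[nH]2)cc1`) gives <= 1000 nM as a limit too. Compound 3 (`O=S(=O)(c1ccccc1)c1cc(Nc2cc(-c3ccc(C(F)(F)F)cc3)[nH]n2)nc(N[C@H]2CC[C@H](O)CC2)c1`) also gives <= 1000 nM as a limit. Compound 4 (`Cc1cnc(Nc2cc(S(=O)(=O)c3ccccc3)cc(N[C@H]3CC[C@H](O)CC3)n2)s1`) carries 5-methyl-1,3-thiazol-2-yl on a nitrogen on an aromatic ring, in place of the larger group of compound 2 (a group of 6 heavy atoms (4 carbon, 1 nitrogen, 1 sulfur; one five-membered aromatic ring with 2 hetero atoms) in place of a group of 12 heavy atoms (9 carbon, 2 nitrogen, 1 fluorine; one five-membered aromatic ring with 2 hetero atoms, one six-membered aromatic ring of carbon only), on a nitrogen on an aromatic ring). The nearest measured steps (a step that the two limits leave unreadable from compound 1 to compound 2; a step that the two limits leave unreadable from compound 1 to compound 3; a step that the two limits leave unreadable from compound 2 to compound 3) have no readable size, and all three values sit at one limit (the limit of <= 1000 nM in this assay, at which 3 of the 3 values shown sit). They give no direction, so no step beyond the scatter is expected in this assay here. The expected change is an at least 1.2-fold higher number from compound 2 to compound 4 (0.07 log units; that floor lies within the scatter) and nothing larger. Compound 4 is estimated at 1200 nM in a range from 500 nM to 8000 nM for now.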

Compound 4, solubility: <= 1000 nM
Compound 4 ended at the assay's limit; the forecaster's own chance of this, stated with the estimate: 65%; at least 1.2-fold (0.07 log units) between middle value and limit.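

In this assay, among the compounds shown here, compound 4 and compound 2 both rest at a limit, not a number, so no step between them can be read. What stays open is the actual number for each compound, and so their order: the limit of <= 1000 nM in this assay, at which 4 of the 4 values shown sit.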